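A Methyl-to-Methoxy Swap Repeated on a Second Core

A few compounds are considered here, and "the series" means these few. Any claim that something is new, unique, unknown or untested is made for them only; others in the source may bear on it.

Measured so far in a functional assay on RAW264.7 cells (Mus musculus) for inhibition, with a stated time of 4 days; a higher number here means a weaker inhibitor, a lower number a stronger inhibitor:
compound 1, `COc1cc(/C=C/C(=O)c2cccc(-n3cc(-c4ccc(C)cc4)nn3)c2)ccc1O`, 15400 nM
compound 2, `COc1ccc(-c2cn(-c3cccc(C(=O)/C=C/c4ccc(O)c(OC)c4)c3)nn2)cc1`, 7900 nM
compound 3, `COc1ccc(/C=C/C(=O)c2cccc(-n3cc(-c4ccc(C)cc4)nn3)c2)cc1O`, 1700 nM

The still unmeasured compound 4, `COc1ccc(-c2cn(-c3cccc(C(=O)/C=C/c4ccc(OC)c(O)c4)c3)nn2)cc1`, is built from compound 3 by the same change that turns compound 1 into compound 2. That change is methoxy in place of methyl on an aromatic carbon in the first pair and methoxy in place of methyl on an aromatic carbon in the second; the surroundings of the place are described in the same words in both, so it counts as the same change. On the first core it made the step of a 1.9-fold lower number from compound 1 to compound 2 (0.29 log units; within the scatter), a small step that does not stand out from the usual scatter of repeated measurements.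

The two cores are themselves related: compound 3 differs from compound 1 by 3-hydroxy-4-methoxyphenyl in place of 4-hydroxy-3-methoxyphenyl on a double-bonded chain carbon bound to a double-bonded chain carbon, the same atoms joined differently, and that rearrangement gave the step of a 9.1-fold lower number from compound 1 to compound 3 (0.96 log units; beyond the scatter). Compound 3 therefore gives the lowest number of the three measured compounds in this assay, and both its steps to the others lie beyond the scatter.

Among the compounds with values here, for compound 4 a step of similar size to the earlier one is expected, because the one measured example of this change is a 1.9-fold lower number from compound 1 to compound 2 (0.29 log units; within the scatter) and nothing here suggests the second core should respond differently. The expected step is a 1.5-fold lower number from compound 3 to compound 4 (0.19 log units; within the scatter). Compound 4 is thus estimated at 1100 nM, with a plausible range from 500 nM to 2500 nM.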

Compound 4, half-maximal inhibitory concentration: 6290 nM
For compound 4 the middle estimate is 5.7-fold (0.76 log units) below the measured one; the whole stated range lies below it.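

In this assay, replacing 4-methylphenyl with 4-methoxyphenyl on the core of compound 3 gave a 3.7-fold higher number from compound 3 to compound 4 (0.57 log units; beyond the scatter), so the change did not carry over from the core of compound 1 in either size or direction: the same change on two cores in this assay, a 1.9-fold lower number (0.29 log units; within the scatter) from compound 1 to compound 2 and a 3.7-fold higher number (0.57 log units; beyond the scatter) from compound 3 to compound 4, 7.2-fold (0.86 log units) apart, beyond the scatter of two such steps

The other change in this set of four behaves the same way, since exchanging 4-hydroxy-3-methoxyphenyl for 3-hydroxy-4-methoxyphenyl gave a 1.3-fold lower number from compound 2 to compound 4 (0.10 log units; within the scatter), far from its earlier effect: the same change on two cores in this assay, a 9.1-fold lower number (0.96 log units; beyond the scatter) from compound 1 to compound 3 and a 1.3-fold lower number (0.10 log units; within the scatter) from compound 2 to compound 4, 7.2-fold (0.86 log units) apart, beyond the scatter of two such steps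

Within the data shown here, this shows that the two changes do not add up in these compounds, so a step measured on one core cannot simply be transferred to the other, although each change has only two examples and the data do not show why the steps differ.

The compounds shown leave open whether the low number of compound 3 depends on methyl itself, or whether an ethyl group, a chlorine or an amine in the same place would act like methyl or like methoxy. They also leave open whether the same dependence would appear with other groups on the hydroxy-bearing ring, such as a second hydroxy or a fluorine.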